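Aryl sulfonamide variation: compound 2 to compound 3

The source may hold more compounds than are shown below. What is called first, only, known or untested is meant among the compounds shown, and "the series" means these compounds.

Measured so far:
compound 1 `CC(=O)c1ccc(OCCCN2CC[C@H](NC(=O)c3ccc(C#N)cc3)C2)cc1`: 6100 nM
compound 2 `O=C(c1ccc(OCCCN2CC[C@H](NS(=O)(=O)c3cccc(F)c3)C2)cc1)C1CC1`: 1600 nM

In an assay on isolated protein for binding affinity to histamine H2 receptor (Homo sapiens) (a lower number here means a stronger inhibitor, a higher number a weaker inhibitor), compound 2 gives the lower of the two numbers; compound 1 sits above it, and that gap lies beyond the scatter. Compound 3 `COc1ccc(S(=O)(=O)N[C@H]2CCN(CCCOc3ccc(C(=O)C4CC4)cc3)C2)cc1` is not yet measured. It differs from compound 2 by 4-methoxyphenyl in place of 3-fluorophenyl on a sulfonyl sulfur. Among the measured compounds shown here, no measured pair covers this change, so its effect in this assay is unknown; a step of no change at the digits printed from compound 2 to compound 3 (within the scatter) is expected, within the scatter and in no firm direction. Compound 3 is estimated at 1600 nM in this assay, with a range from 600 nM to 4500 nM.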

Compound 3, inhibition constant: 1000 nM
The estimate for compound 3 lay 1.6-fold (0.20 log units) above the measured number, and the stated range covers the measured number.
By their numbers in this assay, from the lowest: compounds 3 and 2 (each within the scatter of the next); then compound 1.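

In this assay, among the compounds shown here, 4-methoxyphenyl in place of 3-fluorophenyl on a sulfonyl sulfur gives a 1.6-fold lower number from compound 2 to compound 3 (0.20 log units; within the scatter), the first single-place comparison. At this position, the two aryl groups are not separated, even though 4-methoxyphenyl carries one hydrogen-bond acceptor and 3-fluorophenyl none. No supporting data bear on this result. Still open, from the compounds shown here alone, is whether the same holds for a group without an aromatic ring on the sulfonyl sulfur, such as cyclohexyl or a simple methyl, or for a phenyl bearing an amine or a carboxylic acid.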